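Swapping bromo for hydroxy on the shared core

The compounds below may be only part of what the source reports. "The series", "measured", "known", "first", "only" and "open" are said of these compounds alone.

In a functional assay on J774 cells (Mus musculus) for cytotoxicity, read by resazurin assay (a lower number here means a stronger inhibitor, a higher number a weaker inhibitor), compound 1 (`OCCCCCC(O)c1ccc(-c2ccc(Br)cc2)cc1`) gives 20000 nM while compound 2 (`OCCCCCC(O)c1ccc(-c2ccc(F)cc2)cc1`) gives 18000 nM and so stands level with it within the scatter. Compound 3 (`OCCCCCC(O)c1ccc(-c2ccc(O)cc2)cc1`) has hydroxy in place of bromo on an aromatic carbon, with hydroxy in place of bromo on an aromatic carbon as its whole difference from compound 1. Going by the values given here, with a 1.1-fold lower number from compound 1 to compound 2 (0.05 log units; within the scatter) as the only measured step at this place, for fluoro in place of bromo, no change beyond the scatter is expected in this assay in either direction. Compound 3 is estimated at 18000 nM with 8000 nM to 40000 nM as its expected range. The expected step is a 1.1-fold lower number from compound 1 to compound 3 (0.05 log units; within the scatter) and no more than an estimate.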

Compound 3, half-maximal inhibitory concentration: 15000 nM
The estimate for compound 3 lay 1.2-fold (0.08 log units) above the measured number; the range from low to high includes it.
By their numbers in this assay, from the lowest: compounds 3, 2 and 1 (each within the scatter of the next).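

In this assay, hydroxy on this aromatic carbon gives a 1.3-fold lower number from compound 1 to compound 3 (0.12 log units; within the scatter) and a 1.2-fold lower number from compound 2 to compound 3 (0.08 log units; within the scatter). The step therefore stays within the scatter even when the entering group carries a hydrogen-bond donor and a hydrogen-bond acceptor, which bromo does not, something the fluoro for bromo step alone could not show. Nothing available accounts for this lack of change. On these data alone, whether an amine or a carboxylic acid at this place would move the number beyond the scatter remains open. So does the effect of a shorter chain on the shared core.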